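Swapping the aryl group on the triazole: compound 4 estimated

The compounds below may be only part of what the source reports. "The series", "measured", "known", "first", "only" and "open" are said of these compounds alone.

Measured compounds:
- compound 1, `COc1ccc(-n2nncc2CN2C(=O)C3(C(C#N)=C(N)Oc4c(N)cc5nc6ccccc6nc5c43)c3ccccc32)cc1`; in a functional assay on A549 cells (Homo sapiens) for antiproliferative activity, read by MTT assay, with a stated time of 48 h (on this read-out lower numbers stand for stronger inhibition and higher numbers for weaker inhibition), compound 1 gives only a limit, > 50000 nM.
- compound 2, `COc1ccccc1-n1nncc1CN1C(=O)C2(C(C#N)=C(N)Oc3c(N)cc4nc5ccccc5nc4c32)c2ccccc21`; compound 2 gives 37500 nM.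
- compound 3, `N#CC1=C(N)Oc2c(N)cc3nc4ccccc4nc3c2C12C(=O)N(Cc1cnnn1-c1ccc(F)c(Cl)c1)c1ccccc12`; compound 3 gives 43400 nM.

Compound 3 and compound 2 lie within the scatter of each other, the step being a 1.2-fold higher number from compound 2 to compound 3 (0.06 log units; within the scatter). Against compound 1 both are set against a limit (the limit of > 50000 nM in this assay, at which 1 of the 3 values shown sits), so the steps of an at least 1.3-fold lower number from compound 1 to compound 2 (0.12 log units; that floor lies within the scatter) and an at least 1.1-fold lower number from compound 1 to compound 3 (0.06 log units; that floor lies within the scatter) are floors only. The unmeasured compound 4, `N#CC1=C(N)Oc2c(N)cc3nc4ccccc4nc3c2C12C(=O)N(Cc1cnnn1-c1ccc([N+](=O)[O-])cc1[N+](=O)[O-])c1ccccc12`, differs from compound 3 by 2,4-dinitrophenyl in place of 3-chloro-4-fluorophenyl on an aromatic nitrogen. Every measured step that changes the aryl group on this nitrogen, an at least 1.3-fold lower number from compound 1 to compound 2 (0.12 log units; that floor lies within the scatter), an at least 1.1-fold lower number from compound 1 to compound 3 (0.06 log units; that floor lies within the scatter) and a 1.2-fold higher number from compound 2 to compound 3 (0.06 log units; within the scatter), stayed within the scatter, so for compound 4 in this assay no step beyond the scatter is expected in either direction, a 1.1-fold lower number from compound 3 to compound 4 (0.04 log units; within the scatter). Compound 4 is therefore estimated at 40000 nM, with a range from 15000 nM to 100000 nM.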

Compound 4, half-maximal inhibitory concentration: > 50000 nM
Compound 4: only a limit was reported (the forecaster's own chance of this, stated with the estimate: 35%); middle value at least 1.2-fold (0.09 log units) from the limit.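

With 2,4-dinitrophenyl on this nitrogen, compound 4 also gives only a limit in this assay, the second aryl group shown to do so: the limit of > 50000 nM in this assay, at which 2 of the 4 values shown sit. The steps, an at least 1.1-fold higher number from compound 3 to compound 4 (0.06 log units; that floor lies within the scatter) and an at least 1.3-fold higher number from compound 2 to compound 4 (0.12 log units; that floor lies within the scatter), are floors only, and the step between compound 1 and compound 4 cannot be read. The larger 2,4-dinitrophenyl, with hydrogen-bond acceptors that 3-chloro-4-fluorophenyl lacks, thus gave no step beyond the scatter.

As far as these compounds go, the true values behind both limits stay open. So does what an amine or a carboxylic acid on this aryl ring would do.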